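The compounds below may be only part of what the source reports. "The series", "measured", "known", "first", "only" and "open" are said of these compounds alone.

Compound 2 `CCCCCCCCCCCCCCCCCCNC(=O)[C@H]1CSC(c2ccc(F)c(Br)c2)N1` gives 13500 nM in a functional assay on PC-3 cells (Homo sapiens) for antiproliferative activity, read by sulforhodamine B assay (on this read-out higher numbers stand for weaker inhibition and lower numbers for stronger inhibition), and compound 1 `CCCCCCCCCCCCCCCCCCNC(=O)[C@H]1CSC(Cc2ccccc2)N1` gives 16400 nM; the step of a 1.2-fold lower number from compound 1 to compound 2 (0.08 log units; within the scatter) lies within the scatter, so the two stand level on this read-out. Compound 3 `CCCCCCCCCCCCCCCCCCNC(=O)[C@H]1CSC(c2ccc(C)cc2)N1` differs from compound 2 by 4-methylphenyl in place of 3-bromo-4-fluorophenyl on a saturated ring carbon. Among the measured compounds shown here, the only measured step at this position, a 1.2-fold lower number from compound 1 to compound 2 (0.08 log units; within the scatter), bears on the change and was within the scatter, so no step beyond the scatter in either direction is expected here. Compound 3 is therefore estimated at 15000 nM, with a range from 7000 nM to 32000 nM. The expected step is a 1.1-fold higher number from compound 2 to compound 3 (0.05 log units; within the scatter).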

Compound 3, half-maximal inhibitory concentration: 12800 nM
Compound 3: middle estimate off by 1.2-fold (0.07 log units), on the high side; low and high end bracket the measured number.
By their numbers in this assay, from the lowest: compounds 3, 2 and 1 (each within the scatter of the next).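

In this assay, both new steps (a 1.1-fold lower number from compound 2 to compound 3 (0.02 log units; within the scatter) and a 1.3-fold lower number from compound 1 to compound 3 (0.11 log units; within the scatter)) lie within the scatter, so 4-methylphenyl stands level with 3-bromo-4-fluorophenyl and with benzyl on this saturated ring carbon. Across these three compounds, exchanging the group at this position has produced no step beyond the scatter. No evidence is at hand to explain this result. The compounds shown leave open whether a phenyl carrying an amine or a carboxylic acid at this position would shift the number, and what a shorter chain on the amide nitrogen would do.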